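Compound 3 and the step to compound 4

This account rests on a few compounds, and the source may have more. Where it says the series, first, only, none or still open, it means among the compounds named here.

In a functional assay on MDA-MB-231 cells (Homo sapiens) for cytotoxicity, read by MTT assay, with a stated time of 48 h (on this read-out lower numbers stand for stronger inhibition and higher numbers for weaker inhibition), compound 1 (`Nc1ccc(NC(=O)NCCCCC(c2ccc(F)cc2)c2ccc(F)cc2)cc1`) reaches only a limit of the assay, > 20000 nM. Compound 2 (`O=C(NCCCCC(c1ccc(F)cc1)c1ccc(F)cc1)Nc1cccc(Cl)c1`) gives 5070 nM, and compound 3 (`O=C(NCCCCC(c1ccc(F)cc1)c1ccc(F)cc1)Nc1ccc([N+](=O)[O-])c(Cl)c1`) gives 3470 nM, so these two stand level within the scatter. The measured steps are an at least 3.9-fold lower number from compound 1 to compound 2 (0.59 log units; beyond the scatter), an at least 5.7-fold lower number from compound 1 to compound 3 (0.76 log units; beyond the scatter) and a 1.5-fold lower number from compound 2 to compound 3 (0.16 log units; within the scatter). Compound 4 (`O=C(NCCCCC(c1ccc(F)cc1)c1ccc(F)cc1)c1ccc(Cl)c(C(F)(F)F)c1`) carries 4-chloro-3-(trifluoromethyl)phenyl in place of (3-chloro-4-nitrophenyl)amino on a carbonyl carbon. Going by the values given here, no measured step changes this place, so the closest guide is compound 2 and compound 3, with a 1.5-fold lower number from compound 2 to compound 3 (0.16 log units; within the scatter), and no step beyond the scatter is expected. The estimated change is a 1.2-fold higher number from compound 3 to compound 4 (0.06 log units; within the scatter). Compound 4 is expected at 4000 nM, within an estimated range of 1500 nM to 12000 nM.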

Compound 4, half-maximal inhibitory concentration: 11700 nM
The estimate for compound 4 lay 2.9-fold (0.47 log units) below the measured number; measured number inside the range.
By their numbers in this assay, from the lowest: compounds 3 and 2 (each within the scatter of the next); then compound 4. At a limit, above all of these: compound 1.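

In this assay, this carbonyl carbon proves sensitive to what it carries: with 4-chloro-3-(trifluoromethyl)phenyl in place of the arylamino groups there is a 3.4-fold higher number from compound 3 to compound 4 (0.53 log units; beyond the scatter) and a 2.3-fold higher number from compound 2 to compound 4 (0.36 log units; beyond the scatter), both modest but beyond the scatter. Among the earlier compounds, the only step between two measured numbers, from compound 2 to compound 3, stayed within the scatter. The remaining step of an at least 1.7-fold lower number from compound 1 to compound 4 (0.23 log units; that floor lies within the scatter) starts from a limit and cannot be read as a difference: the limit of > 20000 nM in this assay, at which 1 of the 4 values shown sits.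

The compounds shown leave open whether the change follows from the lost amide-type nitrogen or from the new ring substituents. (4-Chloro-3-(trifluoromethyl)phenyl)amino on this carbonyl carbon would separate the two.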